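Methyl for fluoro on the aryl ring of compound 2

A few compounds are considered here, and "the series" means these few. Any claim that something is new, unique, unknown or untested is made for them only; others in the source may bear on it.

The three compounds measured so far, with their values in a functional assay on A549 cells (Homo sapiens) for cytotoxicity, read by XTT assay, with a stated time of 24 h; a higher number here means a weaker inhibitor, a lower number a stronger inhibitor:
compound 1 `Cn1nnnc1SCC(=O)N/N=C/c1ccccc1[N+](=O)[O-]` — 1600000 nM
compound 2 `Cn1nnnc1SCC(=O)N/N=C/c1cccc(F)c1` — 6320000 nM
compound 3 `COc1ccccc1/C=N/NC(=O)CSc1nnnn1C` — 7000000 nM

Compound 2 sits close to compound 3, the two values lying within the scatter of each other, and well apart from compound 1, whose number is lower by an amount beyond the scatter. Within the data shown here, only one step between measured compounds is available: a 4.4-fold higher number from compound 1 to compound 3 (0.64 log units; beyond the scatter), a modest change and one that concerns a methoxy replacing a nitro group, not the change considered here.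

Compound 4 `Cc1cccc(/C=N/NC(=O)CSc2nnnn2C)c1` differs from compound 2 by methyl in place of fluoro on an aromatic carbon. Among the measured compounds shown here, no measured pair shows a methyl replacing a fluoro on this ring, so nothing directly bears on this step. For the measured compounds named here, the one step known is modest, and the two compounds without a nitro group, compound 2 and compound 3, give numbers within the scatter of each other. On that basis no step beyond the scatter is expected in this assay, in either direction, and the estimate for compound 4 is 6300000 nM with a range from 2500000 nM to 16000000 nM, which means the expected step of a 1.0-fold lower number from compound 2 to compound 4 (0.00 log units; within the scatter).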

Compound 4, half-maximal inhibitory concentration: 2000000 nM
Beside the measured number, compound 4's estimate is 3.2-fold (0.50 log units) above it; the whole stated range lies above it.
By their numbers in this assay, from the lowest: compounds 1 and 4 (each within the scatter of the next); then compounds 2 and 3 (each within the scatter of the next).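

In this assay, methyl in place of fluoro on an aromatic carbon, meta to a large group, gives a 3.2-fold lower number from compound 2 to compound 4 (0.50 log units; beyond the scatter), so this position responds to the exchange of one heavy atom for another, even though neither group carries a hydrogen-bond donor, a hydrogen-bond acceptor or a net charge. Until this result, the only step that could be read was methoxy in place of nitro, a 4.4-fold higher number from compound 1 to compound 3 (0.64 log units; beyond the scatter), so this is the first step shown that involves no nitro group, and the change goes towards a stronger inhibitor, with a size also classed as modest. Nothing available explains why the number falls with this change.

The compounds shown leave open whether an ethyl chain, an amine or a carboxylic acid on this same aromatic carbon would give a number closer to that of the methyl compound or to that of the fluoro compound. Among these compounds, they also leave open whether methyl in place of fluoro would give a similar step elsewhere on the ring, as this single pair is the only reading of the change.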